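Swapping an Anilino Arm for a Nitrophenyl One

The compounds below may be only part of what the source reports. "The series", "measured", "known", "first", "only" and "open" are said of these compounds alone.

Measured compounds:
- compound 1 `N#CC1=C(/N=C/c2ccccc2)N(c2ccccc2)C(=O)N2CCCCC(N3CCCC3)C12` gives 84%
- compound 2 `N#CC1=C(/N=C/Nc2ccccc2)N(c2ccccc2)C(=O)N2CCCCC(N3CCCC3)C12` gives 79.3%

Of the compounds shown here, two sharing one core have been tested in a functional assay on the whole organism (strain albino) for inhibition, with Rattus norvegicus as the target, read by paw edema, with stated times of 1 h and 3 h, at a dose of 20 mmol/kg by the intraperitoneal route; a higher number here means a stronger effect of the compound at the dose given, a lower number a weaker effect. Compound 2 stands at the lower of the two numbers, but its gap to compound 1 is small: the step of a number 4.7 percentage points lower from compound 1 to compound 2 (within the scatter) is within the scatter, so the two cannot be told apart.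

Compound 3 `N#CC1=C(/N=C/c2ccc([N+](=O)[O-])cc2)N(c2ccccc2)C(=O)N2CCCCC(N3CCCC3)C12` has not yet been measured in this assay. It differs from compound 2 as follows: 4-nitrophenyl in place of anilino on a carbon with a double bond to nitrogen

Within the data shown here, only one measured step bears on this change, the step of a number 4.7 percentage points lower from compound 1 to compound 2 (within the scatter), and it shows that exchanging phenyl for anilino on the carbon with a double bond to nitrogen left the number essentially unchanged. Nothing measured here shows what a nitro-bearing phenyl does at that position. With no step beyond the scatter to draw on, the expectation for compound 3 in this assay is a number close to compound 2, a step of a number 0.7 percentage points higher from compound 2 to compound 3 (within the scatter), no larger than the scatter. Compound 3 is therefore estimated at 80%, with a range of 66% to 92%.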

Compound 3, a percentage reported as inhibition, in the whole organism at one dose (the size of the read-out at that dose, not a potency): 91.7%
The estimate for compound 3 lay 11.7 percentage points below the measured number; low and high end bracket the measured number.
By their numbers in this assay, from the lowest: compounds 2, 1 and 3 (each within the scatter of the next, the first and the last beyond it).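

In this assay, among these compounds, the place on the carbon with a double bond to nitrogen now shows that it can shift the number: putting 4-nitrophenyl in place of anilino gives a number 12.4 percentage points higher from compound 2 to compound 3 (beyond the scatter), the first step at this place to clear the usual scatter, though only a modest one. The nitro group alone does not account for a separable gain, since adding nitro in place of hydrogen on an aromatic carbon gives a number 7.7 percentage points higher from compound 1 to compound 3 (within the scatter), so the plain phenyl compound cannot be told apart from either neighbour and only the two ends of the series differ. Nothing available explains why these groups differ in this way.

Going by these compounds, it remains open whether the nitro group matters in itself, or whether an amine or a carboxylic acid on the same phenyl ring would give a similar number. Also open, on these data alone, is how a saturated group such as cyclohexyl or a longer alkyl chain would behave at this place, which would show whether an aromatic ring is needed there at all.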